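The source may hold more compounds than are shown below. What is called first, only, known or untested is meant among the compounds shown, and "the series" means these compounds.

In an ADME assay on S9 fraction from liver (Homo sapiens) for metabolic stability, read by LC-MS, using NADPH, with a stated time of 60 min, tested at 1 uM (a lower number here means that the compound disappears faster, a higher number that the compound lasts longer), compound 1 `Cc1ccccc1N(C)C(=O)c1ccc(-c2ccc(OS(N)(=O)=O)cc2)o1` gives 0.783 h, compound 2 `Cc1ccccc1N(C)C(=O)c1ccc(-c2ccc(OS(N)(=O)=O)c(Cl)c2)o1` gives 0.8 h and compound 3 `Cc1ccccc1N(C)C(=O)c1ccc(-c2ccc(OS(N)(=O)=O)c(F)c2)o1` gives 0.717 h. Compound 1 thus stands level with the other two, as all three numbers lie within the usual scatter of one another.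

Compound 4 `Cc1ccccc1N(C)C(=O)c1ccc(-c2ccc(OS(N)(=O)=O)cc2Cl)o1` differs from compound 1 in one place: chloro in place of hydrogen on an aromatic carbon. This is chloro in place of hydrogen on an aromatic carbon, ortho to a large group and meta to a sulfamoyloxy group.

Among the compounds with values here, two measured steps bear on this change, both made on the same ring. Chloro in place of hydrogen brought a 1.0-fold higher number from compound 1 to compound 2 (0.01 log units; within the scatter), and fluoro in place of hydrogen brought a 1.1-fold lower number from compound 1 to compound 3 (0.04 log units; within the scatter). Neither uses the carbon that carries the chloro in compound 4, so this evidence is indirect. Even so, no shift beyond the scatter is expected in this assay, and the expected step is a 1.0-fold lower number from compound 1 to compound 4 (0.02 log units; within the scatter). Compound 4 is estimated at 0.75 h, with an expected range from 0.45 h to 1.2 h.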

Compound 4, half-life: 0.65 h
Compound 4: the middle estimate sits 1.2-fold (0.06 log units) above what was measured, within the range that was stated.
By their numbers in this assay, from the lowest: compounds 4, 3, 1 and 2 (each within the scatter of the next).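

Within the data shown here, on the carbon ortho to a large group and meta to a sulfamoyloxy group, chloro in place of hydrogen gives a 1.2-fold lower number from compound 1 to compound 4 (0.08 log units; within the scatter) in this assay, the first reading at this carbon. Among these compounds, this position therefore joins the one used in compound 2 and compound 3: a single halogen on this aromatic ring has not moved the half-life beyond normal assay noise at either place. No measurement here explains why the half-life stays so steady at this position.

The compounds shown leave open whether a group other than chloro on this carbon, such as an amine, a carboxylic acid or a longer chain, would shift the half-life beyond the scatter. They also leave open how fluoro would behave at this same carbon.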